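A few compounds are considered here, and "the series" means these few. Any claim that something is new, unique, unknown or untested is made for them only; others in the source may bear on it.

Values in a functional assay on MCF7 cells (Homo sapiens) for cytotoxicity, read by MTT assay, with a stated time of 72 h; a higher number here means a weaker inhibitor, a lower number a stronger inhibitor:
- compound 1 `COc1ccc(-c2ccc(C(=O)Nc3ccc(Oc4ccnc5[nH]ccc45)cc3)nc2)cc1`: > 10000 nM (a limit, not a number)
- compound 2 `Cc1cccc(-c2ccnc(C(=O)Nc3ccc(Oc4ccnc5[nH]ccc45)cc3)c2)c1`: 7470 nM
- compound 3 `Cc1cccc(-c2ccnc(C(=O)Nc3ccc(Oc4ccnc5[nH]ccc45)c(F)c3)c2)c1`: 9120 nM

Compound 3 gives the highest of the two numbers available in this assay; its nearest neighbour is compound 2, and the step of a 1.2-fold higher number from compound 2 to compound 3 (0.09 log units; within the scatter) does not separate the two. For compound 1 this assay reports only a limit, > 10000 nM, a limit of the kind described by the limit of > 10000 nM in this assay, at which 1 of the 3 values shown sits.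

Compound 4 `O=C(Nc1ccc(Oc2ccnc3[nH]ccc23)c(F)c1)c1cc(-c2ccc(C(F)(F)F)cc2)ccn1` differs from compound 3 in one place: 4-(trifluoromethyl)phenyl in place of 3-methylphenyl on an aromatic carbon. The amide, the shared core and the fluoro of compound 3 are kept. Within the data shown here, no measured step changes the aryl group alone; compound 1 and compound 2 differ at the aryl group but also elsewhere, so their two values show only that one sits at a limit and the other is a number. Among the measured compounds shown here, the only measured step, a 1.2-fold higher number from compound 2 to compound 3 (0.09 log units; within the scatter), is within the scatter and concerns a different position. No step beyond the scatter is therefore expected in this assay for the change to compound 4.

Compound 4 is estimated at 9500 nM in this assay, expected between 3000 nM and 30000 nM, with the step of a 1.0-fold higher number from compound 3 to compound 4 (0.02 log units; within the scatter) expected to lie within the scatter; a reported limit rather than a number is a real possibility.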

Compound 4, half-maximal inhibitory concentration: 8550 nM
Estimate against measurement, compound 4: 1.1-fold (0.05 log units) above, within the range that was stated.
By their numbers in this assay, from the lowest: compounds 2, 4 and 3 (each within the scatter of the next). At a limit, above all of these: compound 1.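

In this assay, among these compounds, the aryl group on the aromatic carbon opposite the ring nitrogen is now changed on its own for the first time, and the step, a 1.1-fold lower number from compound 3 to compound 4 (0.03 log units; within the scatter), does not separate the two compounds. The exchange of 3-methylphenyl for 4-(trifluoromethyl)phenyl alters both the substituent on the phenyl and where it stands, yet the readout stays within the scatter, so this one change at this position gives no measurable difference in this assay. Compound 1 is reported only as a limit, not a number, so it gives no step, and it differs from the others in more than one place: the limit of > 10000 nM in this assay, at which 1 of the 4 values shown sits.

Going by these compounds, compounds 3 and 4 change the substituent and its place on the phenyl together, so it remains open what either change does alone, for instance a methyl group at the 4-position or a trifluoromethyl group at the 3-position of the phenyl. On these data alone, it also remains open whether the same flat reading would hold with an amine or a carboxylic acid on the phenyl, or with a saturated ring such as cyclohexyl in place of the phenyl.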